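The source may hold more compounds than are shown below. What is called first, only, known or untested is meant among the compounds shown, and "the series" means these compounds.

Measured so far:
- compound 1, `Cn1c(=O)[nH]c2c(cnn2-c2ccc(Cl)cc2)c1=N`, 37% in an assay on membranes from brain for binding affinity to adenosine receptor A1 (Rattus norvegicus), read by radioligand binding, tested at 20 uM; a lower number here means less inhibition, a higher number more inhibition at the concentration tested (going by the name of the read-out)
- compound 2, `Cn1c(=O)[nH]c2c(cnn2-c2ccc(Br)cc2)c1=N`, 34%

Both compounds share one core and differ only in the group on the six-membered aromatic ring of carbon only. Among the measured compounds shown here, the single measured step, a number 3 percentage points lower from compound 1 to compound 2 (within the scatter), swaps one halogen for another, and compound 2 and compound 1 therefore stand within the scatter of each other; neither number can be called higher or lower than the other on these two values alone.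

Compound 3, `Cn1c(=O)[nH]c2c(cnn2-c2ccc(N)cc2)c1=N`, has not yet been tested in this assay. Its change from compound 2 is amino in place of bromo on an aromatic carbon. For the measured compounds named here, no measured step replaces a halogen with amino, so the one step on record gives no direct guide; it only shows that one exchange at this place left the read-out unchanged within the scatter. The expectation is therefore a step of no clear direction beyond the scatter, a number 4 percentage points lower from compound 2 to compound 3 (within the scatter), with a wide range to admit a shift either way.

Compound 3 is estimated at 30% in this assay, within a range from 8% to 55%.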

Compound 3, a percentage reported as inhibition, at one concentration (the size of the read-out at that concentration, not a potency): 0%
The estimate for compound 3 lay 30 percentage points above the measured number; the measured number lies below the stated range.
By their numbers in this assay, from the lowest: compound 3; then compounds 2 and 1 (each within the scatter of the next).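

At this place on the six-membered aromatic ring of carbon only, para to a large group, the read-out in this assay is clearly sensitive to which group is present: amino in place of bromo gives a number 34 percentage points lower from compound 2 to compound 3 (beyond the scatter), and amino in place of chloro gives a number 37 percentage points lower from compound 1 to compound 3 (beyond the scatter). The earlier halogen exchange had stayed within the scatter, so it could not show this sensitivity, whereas compound 3, with amino carrying a hydrogen-bond donor and a hydrogen-bond acceptor where each halogen counts none, reads 0%. No measurement on hand accounts for this large fall, so the link between those counts and the read-out remains only an observation on these three compounds.

The compounds shown leave open whether the fall is particular to amino or would also appear with other groups at this place, such as hydroxyl, methoxy or acetamido, or with a methyl or fluoro in place of the halogens. Since each number comes from a single tested concentration, they also leave open how far the compounds differ in potency.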